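The source may hold more compounds than are shown below. What is called first, only, known or untested is meant among the compounds shown, and "the series" means these compounds.

In a functional assay on CCRF-CEM cells (Homo sapiens) for cytotoxicity, read by sulforhodamine B assay, with a stated time of 48 h (on this read-out lower numbers stand for stronger inhibition of growth and higher numbers for weaker inhibition of growth), compound 1 `ClCc1ccc(Cn2cnc3c(Cl)ncnc32)cc1` gives 510 nM. Compound 3 `ClCc1ccc(Cn2cnc3c(Cl)nc(Cl)nc32)cc1`, which gives 1950 nM, carries chloro in place of hydrogen on an aromatic carbon on the core of compound 1, and that change produced a 3.8-fold higher number from compound 1 to compound 3 (0.58 log units; beyond the scatter). For the measured compounds named here, compound 2 `ClCc1ccccc1Cn1cnc2ncnc(Cl)c21` gives 1440 nM in this assay, a number that lies within the scatter of the one for compound 3; how the core of compound 2 differs from that of compound 1 is not broken down here beyond the two having the same atoms joined differently. Compound 4 `ClCc1ccccc1Cn1cnc2nc(Cl)nc(Cl)c21` is not yet measured. It carries chloro in place of hydrogen on an aromatic carbon, and since the surroundings of that position are described in the same words as for compound 3, the change is the same. Compound 4 is expected to show a 3.8-fold higher number from compound 2 to compound 4 (0.58 log units; beyond the scatter), because the same change in compound 3 gave a 3.8-fold higher number from compound 1 to compound 3 (0.58 log units; beyond the scatter). The estimate for compound 4 is 5500 nM, with a range from 2500 nM to 12000 nM.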

Compound 4, concentration for 50% growth inhibition: 100 nM
Estimate against measurement, compound 4: 55-fold (1.74 log units) above; measured number below the stated range.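

In this assay, chloro in place of hydrogen on an aromatic carbon gave a 14-fold lower number from compound 2 to compound 4 (1.16 log units; beyond the scatter), and set beside the earlier step, the same change did not carry over from one core to the other: the same change on two cores in this assay, a 3.8-fold higher number (0.58 log units; beyond the scatter) from compound 1 to compound 3 and a 14-fold lower number (1.16 log units; beyond the scatter) from compound 2 to compound 4, 55-fold (1.74 log units) apart, beyond the scatter of two such steps. In this series, then, a step read on one core was no reliable guide to the same step on the other. The two pairs do not show which feature of the differently joined cores goes with this split, nor what the change would do on any third core.

The compounds shown leave open whether an amine or a methoxy group at this place would split in the same way on the two cores. They also leave open whether bromo would follow chloro on either core.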